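Swapping the Positions of the Chloro and Methyl Groups

A few compounds are considered here, and "the series" means these few. Any claim that something is new, unique, unknown or untested is made for them only; others in the source may bear on it.

Compound 3 `Cc1ccc(Nc2nc(N)nc(COc3ccc4c(C)cc(=O)oc4c3)n2)cc1Cl` stands lowest of the three measured compounds in an assay on COS-7 cells for agonist activity at Free fatty acid receptor 1 (Homo sapiens), read by scintillation counting and inositol phosphate accumulation, with a stated time of 90 min; a higher number here means that more compound is needed for the effect, a lower number that less compound is needed: compound 3 gives 140 nM, whereas compound 1 `Cc1ccc(Nc2nc(N)nc(COc3ccc4c(C)cc(=O)oc4c3)n2)cc1` gives 1790 nM and compound 2 `Cc1cc(=O)oc2cc(OCc3nc(N)nc(Nc4ccc5c(c4)COC5)n3)ccc12` gives 1330 nM. The step of a 13-fold lower number from compound 1 to compound 3 (1.11 log units; beyond the scatter) came from adding a chloro group, and the step of a 9.5-fold lower number from compound 2 to compound 3 (0.98 log units; beyond the scatter) from exchanging the whole aryl group. Compound 4 `Cc1cc(Nc2nc(N)nc(COc3ccc4c(C)cc(=O)oc4c3)n2)ccc1Cl` keeps every atom of compound 3 but joins them differently: 4-chloro-3-methylphenyl in place of 3-chloro-4-methylphenyl on a nitrogen on an aromatic ring. For the measured compounds named here, no measured step exchanges the places of these two groups, so the size of this change is not anchored. The step of a 13-fold lower number from compound 1 to compound 3 (1.11 log units; beyond the scatter) shows that the chlorine matters, not whether its placement does, so a move toward a higher number is plausible but uncertain. Compound 4 is expected to give 400 nM (range 100 nM to 1600 nM), an expected step of a 2.9-fold higher number from compound 3 to compound 4 (0.46 log units; beyond the scatter).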

Compound 4, half-maximal effective concentration: 240 nM
For compound 4 the middle estimate is 1.7-fold (0.22 log units) above the measured one, within the range that was stated.
By their numbers in this assay, from the lowest: compounds 3 and 4 (each within the scatter of the next); then compounds 2 and 1 (each within the scatter of the next).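

Exchanging the places of the chloro and methyl groups gives a 1.7-fold higher number from compound 3 to compound 4 (0.23 log units; within the scatter) in this assay, so at this position the two arrangements cannot be told apart. Compound 4 also holds the gain over the other aryl groups, with a 7.5-fold lower number from compound 1 to compound 4 (0.87 log units; beyond the scatter) and a 5.5-fold lower number from compound 2 to compound 4 (0.74 log units; beyond the scatter) as the steps. Nothing measured here explains these results. Still open, as far as these compounds go, is whether a fluoro, bromo or trifluoromethyl group could take the place of the chloro in either arrangement. Also open, from the compounds shown here alone, is whether the methyl group is needed at all, which a phenyl ring carrying chloro alone would test.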